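A pyridin-3-yl swap on compound 2

The source may report more compounds than this note shows. Statements on the series, on what has been measured and on what is new or still open speak of the compounds shown alone.

Measured so far in a functional assay on KG-1 cells (Homo sapiens) for cytotoxicity, read by luminescence and CellTiter-Glo, with a stated time of 3 days (on this read-out higher numbers stand for weaker inhibition and lower numbers for stronger inhibition), as follows:
- compound 1 `O=C(Nc1cc(F)cc(F)c1)c1ccc2cccnc2c1O` gives 3340 nM
- compound 2 `N#Cc1ccc(NC(=O)c2cc(-c3ccncc3)ccc2O)cc1` gives 7990 nM
- compound 3 `Cc1ccc(C(=O)Nc2ccc(C#N)cc2)c(O)c1` gives 2560 nM

Compound 2 carries the highest number of the three, which makes it the weakest here, and its gaps to compound 1 and to compound 3 both lie beyond the scatter. The next compound, compound 4 `N#Cc1ccc(NC(=O)c2cc(-c3cccnc3)ccc2O)cc1`, differs from it in one group, pyridin-3-yl in place of pyridin-4-yl on an aromatic carbon with pyridin-3-yl in place of pyridin-4-yl on an aromatic carbon, para to a hydroxy group.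

Among the measured compounds shown here, no two measured compounds differ in one place only, so the data give no direct size for such a swap. In this assay no step beyond the scatter is expected, an expectation anchored on compound 2 at 7990 nM and on the equal counts of the two groups. The estimated change is a 1.2-fold lower number from compound 2 to compound 4 (0.09 log units; within the scatter) and would stay within the scatter. Compound 4 is expected at 6500 nM with an estimated range from 2500 nM to 15000 nM once it is measured.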

Compound 4, half-maximal inhibitory concentration: 8330 nM
Estimate against measurement, compound 4: 1.3-fold (0.11 log units) below; measured number inside the range.
By their numbers in this assay, from the lowest: compounds 3 and 1 (each within the scatter of the next); then compounds 2 and 4 (each within the scatter of the next).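

In this assay the set now holds its first pair differing in one place, which gives a 1.0-fold higher number from compound 2 to compound 4 (0.02 log units; within the scatter) for pyridin-3-yl in place of pyridin-4-yl on an aromatic carbon para to a hydroxy group. The earlier compounds shown here gave no size for any single change, and this pair shows that, at this position, the two pyridinyl groups cannot be told apart in this read-out. Nothing measured in the data accounts for this result.

From the compounds shown here alone, whether a different kind of group at this position, such as an amine, a carboxylic acid or a pyridin-2-yl group, would shift the number beyond the scatter remains open. Going by these compounds, it also remains open whether the same swap would give a similar result on the core of compound 1.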